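A few compounds are considered here, and "the series" means these few. Any claim that something is new, unique, unknown or untested is made for them only; others in the source may bear on it.

Of the compounds shown here, two have been measured so far. Compound 1 `O=C(/C=C/c1ccncc1-c1ccc2[nH]ccc2c1)N1CCOCC1` gives 97% in an assay on a protein complex for inhibition of CDK8/Cyclin C (Homo sapiens), with a stated time of 1 h, tested at 10 uM; on this read-out higher numbers stand for more inhibition at the one concentration tested (going by the name of the read-out) and lower numbers for less inhibition. Compound 2 `CCOC(=O)/C=C/c1ccncc1-c1ccc2c(ccn2C)c1` gives 100% in this assay. The two numbers lie within the usual scatter of repeated measurements of each other, so the inhibition of the two compounds in this assay is to be read as level; both numbers sit high on the scale of this read-out at the single concentration tested.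

The next compound, compound 3 `Cn1ccc2cc(-c3cnccc3/C=C/C(=O)N3CCOCC3)ccc21`, shares the core of compound 2 and differs from it in one place: morpholin-4-yl in place of ethoxy on a carbonyl carbon. The same group that enters here, the morpholin-4-yl on the carbonyl carbon, is already present in compound 1, where it goes together with a high reading of 97% in this assay.

For the measured compounds named here, no step between measured compounds connects this change directly, so the expectation rests on the two readings alone. Because compound 2 already gives 100% in this assay, there is little room for an upward move, and the step from compound 2 to compound 3 is expected to be a number 2 percentage points lower from compound 2 to compound 3 (within the scatter), none beyond the scatter. Compound 3 is estimated to give 98% in this assay, within a range from 90% to 100%.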

Compound 3, a percentage reported as inhibition, at one concentration (the size of the read-out at that concentration, not a potency): 97%
Beside the measured number, compound 3's estimate is 1 percentage points above it; the measured number falls inside the stated range.
By their numbers in this assay, from the lowest: compounds 1, 3 and 2 (each within the scatter of the next).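

In this assay, morpholin-4-yl in place of ethoxy on the carbonyl carbon gives a number 3 percentage points lower from compound 2 to compound 3 (within the scatter) and so does not separate the two compounds, even though the entering group brings a six-membered non-aromatic ring and more heavy atoms. The second new comparison concerns a different place: methyl in place of hydrogen on the aromatic nitrogen gives no change at the digits printed from compound 1 to compound 3 (within the scatter) and so also leaves the reading level, which shows that neither change moves this read-out at the one concentration tested. All three readings sit high on the scale, so they rank nothing in potency, and no separate measurement bears on this result.

Open, going by these compounds, is how the carbonyl carbon would read with a different kind of group, such as a free carboxylic acid or piperazin-1-yl, and how the aromatic nitrogen would read with a longer chain such as propyl in place of methyl. Also open, on these data alone, is whether compound 2 and compound 3 would stay level at a concentration low enough to bring the inhibition down from the top of the scale.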